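The compounds below may be only part of what the source reports. "The series", "measured", "known", "first", "only" and "open" are said of these compounds alone.

Compound 1 `FC(F)(F)c1ccc(CSc2nc(N3CCCCC3)c3ccccc3n2)cc1` gives 18600 nM in a functional assay on MGC-803 cells (Homo sapiens) for cytotoxicity, read by MTT assay, with a stated time of 72 h; on this read-out lower numbers stand for stronger inhibition and higher numbers for weaker inhibition. Compound 2 `COc1ccccc1Nc1nc(SCc2ccc(C(F)(F)F)cc2)nc2ccccc12` gives > 50000 nM in this assay, which is a limit of the assay and not a number. Compound 3 `CCOc1ccccc1Nc1nc(SCc2ccc(C(F)(F)F)cc2)nc2ccccc12` gives > 50000 nM in this assay, again a limit and not a number.

Compound 3 therefore stands at the limit of > 50000 nM in this assay, at which 2 of the 3 values shown sit, so its place among the measured compounds is known only as a floor of weakness, not as a value. Going by the values given here, compound 1 is the only compound with a number. Replacing its piperidin-1-yl by an arylamino group weakened cytotoxicity in both cases: an at least 2.6-fold higher number from compound 1 to compound 2 (0.42 log units; beyond the scatter) and an at least 2.6-fold higher number from compound 1 to compound 3 (0.42 log units; beyond the scatter). Between the two arylamino compounds the step is not readable: a step that the two limits leave unreadable from compound 2 to compound 3.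

Compound 4 `FC(F)(F)c1ccc(CSc2nc(Nc3cccc(Br)c3)c3ccccc3n2)cc1` differs from compound 3 by 3-bromophenyl in place of 2-ethoxyphenyl on a nitrogen on an aromatic ring. Among the compounds with values here, no measured step exchanges one aryl group for another on this nitrogen, so the only bearing evidence is that both arylamino compounds so far sit at the limit. Compound 4 is expected to remain weak in this assay, with the step of an at least 1.2-fold lower number from compound 3 to compound 4 (0.09 log units; that floor lies within the scatter) estimated as not beyond the scatter. Compound 4 is estimated at 40000 nM in this assay, with a range from 12000 nM to 120000 nM, and a real chance that only a limit is reported.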

Compound 4, half-maximal inhibitory concentration: 23700 nM
The estimate for compound 4 lay 1.7-fold (0.23 log units) above the measured number; the measured number falls inside the stated range.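

In this assay, the aryl group on this nitrogen proves able to move the read-out off the limit, with an at least 2.1-fold lower number from compound 3 to compound 4 (0.32 log units; beyond the scatter) and an at least 2.1-fold lower number from compound 2 to compound 4 (0.32 log units; beyond the scatter). The replacement of piperidin-1-yl by an arylamino group therefore does not always cost activity, for the 3-bromophenyl case gives a 1.3-fold higher number from compound 1 to compound 4 (0.11 log units; within the scatter), while the 2-methoxyphenyl and 2-ethoxyphenyl cases stay beyond the scatter from compound 1. Both of those steps from compound 2 and compound 3 are only floors, as each of these two compounds is known only by a limit of the assay and not by a number: the limit of > 50000 nM in this assay, at which 2 of the 4 values shown sit.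

The compounds shown leave open whether the step follows the bromine itself or the loss of the alkoxy group, and a methoxy or a chloro group in place of the bromine would separate these readings. On these data alone, it also remains open what an unsubstituted phenyl or a benzyl on this nitrogen would give, and whether any group here would reach a clearly lower number than compound 1 does.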